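Naphthyl pyrazolines: dichlorophenyl swap at the saturated ring carbon

A few compounds are considered here, and "the series" means these few. Any claim that something is new, unique, unknown or untested is made for them only; others in the source may bear on it.

Measured so far:
compound 1, `CC(=O)N1N=C(c2ccccc2)CC1c1ccc(N(C)C)cc1` — 12000 nM
compound 2, `CC(=O)N1N=C(c2cccc3ccccc23)CC1c1ccc2ccccc2c1` — 250 nM
compound 3, `O=CCN1N=C(c2ccc3ccccc3c2)CC1c1ccccc1` — 21500 nM

Three compounds share the five-membered core with two nitrogens. In a functional assay on OVCAR cells (Homo sapiens) for cytotoxicity, read by sulforhodamine B assay, with a stated time of 48 h (on this read-out lower numbers stand for stronger inhibition and higher numbers for weaker inhibition), compound 1 gives 12000 nM, compound 2 gives 250 nM and compound 3 gives 21500 nM. Compound 3 has the highest number of the three; its gap to compound 1 lies within the scatter, so no order between those two can be read, while compound 2 sits far below both, beyond the scatter. Among the three, compound 2 is the only one carrying two naphthyl rings.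

Compound 4, `O=CCN1N=C(c2ccc3ccccc3c2)CC1c1cccc(Cl)c1Cl`, is not yet measured. It differs from compound 3 in one place: 2,3-dichlorophenyl in place of phenyl on a saturated ring carbon. Going by the values given here, no measured pair shows this exact change, so the size of the step is open. The shared observation is that the larger aryl pair in compound 2 goes with the lowest number, 250 nM, whereas compound 3 with a plain phenyl stands at 21500 nM. On that basis a modest drop in number is expected for compound 4, with a step of a 2.7-fold lower number from compound 3 to compound 4 (0.43 log units; beyond the scatter) in this assay, though a result within the scatter would not be surprising. Compound 4 is estimated at 8000 nM, with a range of 2500 nM to 25000 nM.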

Compound 4, half-maximal inhibitory concentration: 15100 nM
The estimate for compound 4 lay 1.9-fold (0.28 log units) below the measured number; the range from low to high includes it.
By their numbers in this assay, from the lowest: compound 2; then compounds 1, 4 and 3 (each within the scatter of the next).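

In this assay, going by these compounds alone, the first pair that differs only on this saturated ring carbon gives a 1.4-fold lower number from compound 3 to compound 4 (0.15 log units; within the scatter), so 2,3-dichlorophenyl in place of phenyl produces no readable change at this position. With the formylmethyl group and the naphthyl group held fixed, this change therefore does not separate compound 4 from compound 3, and the pair gives no sign that substitution on this phenyl ring moves the number in either direction. No accompanying measurement bears on this result.

One pair with a single substitution pattern cannot show whether this position is insensitive in general, and a carboxylic acid, a primary amine or a longer chain ending in a morpholine on the same ring carbon would test it with groups of a very different kind. Within the data shown here, it also remains open whether 2,3-dichlorophenyl would give a readable step if the formylmethyl group were replaced by an acetyl group, since no pair here shows that change on its own.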